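A few compounds are considered here, and "the series" means these few. Any claim that something is new, unique, unknown or untested is made for them only; others in the source may bear on it.

Of the compounds shown here, two built on a shared core have been measured in an assay on T47D cells for inhibition of 17-beta-hydroxysteroid dehydrogenase type 1 (Homo sapiens), read by HPLC, with a stated time of 24 h; a higher number here means a weaker inhibitor, a lower number a stronger inhibitor. Compound 1 `Cc1ccccc1N(C)C(=O)c1ccc(-c2ccc(O)cc2Cl)o1` gives 14 nM in this assay. Compound 2 `Cc1ccc(F)cc1N(C)C(=O)c1ccc(-c2ccc(O)cc2)o1` gives 12 nM in this assay; this is the smaller of the two numbers, but the gap to compound 1 lies within the usual scatter, so the two cannot be told apart. Compound 3 `Cc1ccncc1N(C)C(=O)c1ccc(-c2ccc(O)cc2)o1` has not yet been measured. It differs from compound 2 in one place: 4-methylpyridin-3-yl in place of 5-fluoro-2-methylphenyl on an amide-type nitrogen. Among the compounds with values here, no step between measured compounds shows what such an exchange does, so the expectation can rest only on the two values at hand, which sit close together. Because both compound 1 and compound 2 give 12 nM or near it, a modest move is expected, if any beyond the scatter, and more likely upward than downward. For compound 3 the estimate in this assay is 22 nM, with a range from 8 nM to 60 nM. The step this estimate implies is expected to be a 1.8-fold higher number from compound 2 to compound 3 (0.26 log units; within the scatter).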

Compound 3, half-maximal inhibitory concentration: 64 nM
Beside the measured number, compound 3's estimate is 2.9-fold (0.46 log units) below it; the measured number lies above the stated range.
By their numbers in this assay, from the lowest: compounds 2 and 1 (each within the scatter of the next); then compound 3.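

Within the data shown here, the step of a 5.3-fold higher number from compound 2 to compound 3 (0.73 log units; beyond the scatter) in this assay is the first reading of what an exchange on the amide-type nitrogen can do, and it lies beyond the scatter. It shows that this position does not treat all six-membered aromatic rings alike: here, 4-methylpyridin-3-yl gives weaker inhibition than 5-fluoro-2-methylphenyl. No measurement at hand explains the loss.

The exchange alters more than one feature at once, adding a ring nitrogen and removing the fluorine, so this single step cannot show which of them matters, or whether both do. Also open, on these data alone, is how this position would respond to a phenyl ring carrying an amine or a carboxylic acid in place of the fluorine.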